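Compound 4: what a larger amide-nitrogen group may do

The source may hold more compounds than are shown below. What is called first, only, known or untested is meant among the compounds shown, and "the series" means these compounds.

- Compound 1 `O=C(CCN1CCN(c2ccnc3cc(Cl)ccc23)CC1)N/N=C/c1c[nH]c2ccccc12`: 5700 nM
- Compound 2 `NNC(=O)CCN1CCN(c2ccnc3cc(Cl)ccc23)CC1`: > 100000 nM (a limit)
- Compound 3 `COc1cc(/C=N/NC(=O)CCN2CCN(c3ccnc4cc(Cl)ccc34)CC2)c(Br)c(OC)c1OC`: 9600 nM

In an ADME assay on cells (Splenocyte, Mus musculus, strain BALB/c) for cytotoxicity, read by thymidine incorporation, with a stated time of 24 h (on this read-out lower numbers stand for stronger inhibition and higher numbers for weaker inhibition), compound 2 reads > 100000 nM as a limit of the assay, not a number.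

The change leading to compound 4 `O=C(CCN1CCN(c2ccnc3cc(Cl)ccc23)CC1)N/N=C/c1cccc(Cl)c1` is a group of 9 heavy atoms (7 carbon, 1 nitrogen, 1 chlorine; one six-membered aromatic ring of carbon only) in place of one nitrogen atom, on an amide-type nitrogen and compound 4 awaits measurement. Among the compounds with values here, the one measured step of this kind runs the other way, with an at least 17-fold higher number from compound 1 to compound 2 (1.24 log units; beyond the scatter) when one nitrogen atom took the place of a larger group. Compound 1 gives 5700 nM and compound 3, also with a larger group on that nitrogen, gives 9600 nM in this assay as well. A large fall in the number is therefore expected, with an at least 13-fold lower number from compound 2 to compound 4 (1.12 log units; beyond the scatter) as the estimate. Compound 4 is expected near 7500 nM (estimated range 3000 nM to 20000 nM).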

Compound 4, half-maximal inhibitory concentration: > 100000 nM
Compound 4 ended at the assay's limit (the forecaster's own chance of this, stated with the estimate: 3%); middle value at least 13-fold (1.12 log units) away from the limit.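

In this assay, a larger group on this amide-type nitrogen does not by itself bring a measurable value. The group's identity counts, with an at least 17-fold higher number from compound 1 to compound 4 (1.24 log units; beyond the scatter) when 3-chlorophenyl replaces 1H-indol-3-yl. The step from compound 2 to compound 4 cannot be read, since both ends are limits of the assay and not numbers: the limit of > 100000 nM in this assay, at which 2 of the 4 values shown sit.

Still open, as far as these compounds go, is whether the chlorine or the loss of the indole ring matters more. A plain phenyl group in the same place would help separate the two.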